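A few compounds are considered here, and "the series" means these few. Any claim that something is new, unique, unknown or untested is made for them only; others in the source may bear on it.

Compounds measured in a functional assay on MCF7 cells (Homo sapiens) for antiproliferative activity, read by MTT assay, with a stated time of 72 h; a lower number here means a stronger inhibitor, a higher number a weaker inhibitor:
Compound 1 `COc1cc(-n2cnc3ccc(-c4ccc(C(C)=O)cc4)cc32)cc(OC)c1OC`: 1540 nM
Compound 2 `COc1cc(-n2cnc3ccc(-c4cccc(C)c4C)cc32)cc(OC)c1OC`: 2150 nM
Compound 3 `COc1cc(-n2cnc3ccc(-c4cccc(N)c4)cc32)cc(OC)c1OC`: 180 nM

Compound 1 holds the second highest of the three numbers in this assay. Its nearest neighbour is compound 2, with a 1.4-fold higher number from compound 1 to compound 2 (0.14 log units; within the scatter); the furthest is compound 3, with an 8.6-fold lower number from compound 1 to compound 3 (0.93 log units; beyond the scatter).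

Compound 4 `COc1cccc(-c2ccc3ncn(-c4cc(OC)c(OC)c(OC)c4)c3c2)c1` is the next variant on the same core. Relative to compound 1 the difference is: 3-methoxyphenyl in place of 4-acetylphenyl on an aromatic carbon

Going by the values given here, two measured steps bear on this. Swapping the 4-acetylphenyl for 2,3-dimethylphenyl gave a 1.4-fold higher number from compound 1 to compound 2 (0.14 log units; within the scatter), whereas swapping it for 3-aminophenyl gave an 8.6-fold lower number from compound 1 to compound 3 (0.93 log units; beyond the scatter); between those two, a 12-fold lower number from compound 2 to compound 3 (1.08 log units; beyond the scatter). The entering 3-methoxyphenyl, like 3-aminophenyl, carries a single group with one hydrogen-bond acceptor, but without the donor of compound 3, so a step smaller than that to compound 3 is expected, still pointing toward a lower number. Compound 4 is therefore expected to show a 2.6-fold lower number from compound 1 to compound 4 (0.41 log units; beyond the scatter), giving an estimated 600 nM with a range from 200 nM to 1800 nM.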

Compound 4, half-maximal inhibitory concentration: 1610 nM
Compound 4: middle estimate off by 2.7-fold (0.43 log units), on the low side; the range from low to high includes it.
By their numbers in this assay, from the lowest: compound 3; then compounds 1, 4 and 2 (each within the scatter of the next).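

In this assay the 3-methoxyphenyl group on this aromatic carbon cannot be told apart from 4-acetylphenyl (a step of a 1.0-fold higher number from compound 1 to compound 4 (0.02 log units; within the scatter)) or from 2,3-dimethylphenyl (a step of a 1.3-fold lower number from compound 2 to compound 4 (0.13 log units; within the scatter)), so compounds 1, 2 and 4 now form one level. Going by these compounds alone, the single change of methoxy in place of amino, with the substituent's place on the phenyl ring unchanged, gives an 8.9-fold higher number from compound 3 to compound 4 (0.95 log units; beyond the scatter) and so ties the low number of compound 3 to the amino group rather than to a substituent at that place alone. Nothing available explains this difference.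

Still open, on these data alone, is whether a hydroxyl or a methylamino group in place of the methoxy of compound 4 would fall with compound 3 or with the level of compounds 1, 2 and 4. Also open, as far as these compounds go, is whether the amino effect holds on other phenyl substitution patterns, such as a 4-aminophenyl group.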